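A Single Swap on the Sulfonyl Sulfur

A few compounds are considered here, and "the series" means these few. Any claim that something is new, unique, unknown or untested is made for them only; others in the source may bear on it.

Three compounds have numbers in an ADME assay on J774.A1 cells (Mus musculus) for cytotoxicity, read by MTT assay, with a stated time of 72 h; a higher number here means that more compound is tolerated, a lower number that less compound is tolerated. Compound 1 (`N/C(=N/O)c1ccc(C2=C(S(=O)(=O)c3ccc(F)cc3)CC(c3ccccc3)(c3ccccc3)O2)cc1`) gives 10200 nM, compound 3 (`CC1(c2ccc(-c3cccc([N+](=O)[O-])c3)cc2)CC(S(=O)(=O)c2ccc(F)cc2)=C(c2ccc(/C(N)=N\O)cc2)O1`) gives 11100 nM, and compound 2 (`CC1(Cc2ccccc2)CC(S(=O)(=O)c2c(F)cccc2F)=C(c2ccc(/C(N)=N\O)cc2)O1`) gives 27000 nM. Compound 2 thus stands highest of the three, and the other two numbers lie below it by more than the usual scatter.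

Compound 4 (`CC1(Cc2ccccc2)CC(S(=O)(=O)c2ccccc2C(F)(F)F)=C(c2ccc(/C(N)=N\O)cc2)O1`) has not yet been measured. It departs from compound 2 in one place: 2-(trifluoromethyl)phenyl in place of 2,6-difluorophenyl on a sulfonyl sulfur, with 2-(trifluoromethyl)phenyl in place of 2,6-difluorophenyl on a sulfonyl sulfur. The measured compounds differ from one another in more than one place, so none of them isolates this change, and any forecast is loose. Because compound 2 stands at 27000 nM, the top of the numbers seen so far, a downward move is thought the likelier direction. The expected change is small and is estimated to stay within the scatter, a 1.5-fold lower number from compound 2 to compound 4 (0.18 log units; within the scatter). In this assay, the estimate for compound 4 is 18000 nM, with an expected range of 9000 nM to 36000 nM.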

Compound 4, half-maximal cytotoxic concentration: 23500 nM
The estimate for compound 4 lay 1.3-fold (0.12 log units) below the measured number; low and high end bracket the measured number.
By their numbers in this assay, from the lowest: compounds 1 and 3 (each within the scatter of the next); then compounds 4 and 2 (each within the scatter of the next).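

In this assay the swap of 2,6-difluorophenyl for 2-(trifluoromethyl)phenyl on a sulfonyl sulfur reads as a 1.1-fold lower number from compound 2 to compound 4 (0.06 log units; within the scatter) and so gives the first view of a single change at this position. The entering group carries more heavy atoms than the one it replaces, with the same counts of hydrogen-bond donors and acceptors and no net charge, yet for this pair the assay does not separate the two groups. Nothing available accounts for this outcome.

On these data alone, it remains open whether the two numbers would still match with a different kind of group on a sulfonyl sulfur, such as a phenyl ring bearing an amine or a carboxylic acid, or a straight alkyl chain. As far as these compounds go, it is also open whether the same swap would read alike on the cores of compound 1 and compound 3, which differ from compound 2 in more than one place.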